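From a Hydroxymethylpyridinyl Alkyne to a Fluoropyridinyl Alkene

This account rests on a few compounds, and the source may have more. Where it says the series, first, only, none or still open, it means among the compounds named here.

Three compounds share one core. Compound 1 `Cc1ccc(-n2nccn2)c(C(=O)N2C[C@H](C#Cc3cccnc3)CC[C@H]2C)c1` was tested in a functional assay on isolated protein for antagonist activity at Orexin receptor type 2 (Homo sapiens), read by FLIPR and calcium flux (a higher number here means a weaker inhibitor, a lower number a stronger inhibitor), and compound 1 gave 28 nM. Compound 2 `Cc1ccc(-n2nccn2)c(C(=O)N2C[C@H](C#Cc3ccc(CO)cn3)CC[C@H]2C)c1` carries a different group on the saturated ring carbon, but in this assay compound 2 is recorded as "not determined" (no result reported), so it stands nowhere on the scale yet. Compound 3 `Cc1ccc(-n2nccn2)c(C(=O)N2C[C@H](/C=C\c3ccc(F)cn3)CC[C@H]2C)c1` differs from compound 2 in one place: 2-(5-fluoropyridin-2-yl)ethenyl in place of 2-(5-(hydroxymethyl)pyridin-2-yl)ethynyl on a saturated ring carbon. Among the measured compounds shown here, with no value for compound 2, no measured step anchors this change; the only reference point is compound 1, which reached 28 nM with a related pyridinyl alkyne on the same ring carbon. The swap of a triple bond for a double bond and of a hydroxymethyl group for a fluorine is expected to shift inhibition only within the usual scatter, in no firm direction. Compound 3 is therefore estimated at 45 nM, with a range from 10 nM to 250 nM.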

Compound 3, half-maximal inhibitory concentration: 417 nM
The estimate for compound 3 lay 9.3-fold (0.97 log units) below the measured number; the measured number lies above the stated range.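

In this assay this saturated ring carbon proves sensitive to what it carries: putting 2-(5-fluoropyridin-2-yl)ethenyl in place of 2-(pyridin-3-yl)ethynyl gives a 15-fold higher number from compound 1 to compound 3 (1.17 log units; beyond the scatter) and so a clearly weaker inhibitor. Compound 2 has no number, and the step from it to compound 3 cannot be read. Nothing measured here explains the loss of inhibition.

Compound 1 and compound 3 differ at once in the triple or double bond, in the point of attachment on the pyridine and in the fluorine, and the compounds shown cannot separate these three changes. From the compounds shown here alone, whether a plain 2-(pyridin-3-yl)ethenyl group, or a pyridine carrying an amine in place of the fluorine, would bring inhibition back toward that of compound 1 also stays open.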